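A few compounds are considered here, and "the series" means these few. Any claim that something is new, unique, unknown or untested is made for them only; others in the source may bear on it.

Three close relatives were tested in a functional assay on LM7 cells (Homo sapiens) for cytotoxicity, read by MTT assay, with a stated time of 72 h; a higher number here means a weaker inhibitor, a lower number a stronger inhibitor. Compound 1, `O=c1cc(CSc2nc3ccccc3s2)oc2ccc(Cl)cc12`, gives > 25000 nM in this assay, which is a limit of the assay rather than a number. Compound 2, `Cc1ccc2oc(CSc3nc4nc(C)cc(C)n4n3)cc(=O)c2c1`, gives > 25000 nM in this assay, again a limit. Compound 3, `Cc1cc(C)n2nc(SCc3cc(=O)c4cc(Cl)ccc4o3)nc2n1`, gives > 25000 nM in this assay, also a limit. All three sit at the limit of > 25000 nM in this assay, at which 3 of the 3 values shown sit. Compound 2 differs from compound 3 by a single change, (methyl in place of chloro on an aromatic carbon), and the step that the two limits leave unreadable from compound 3 to compound 2 cannot be sized, since both ends are limits. How the core of compound 1 differs from the core of compound 3 is not broken down here. Within the data shown here, compound 4, `Cc1ccc2oc(CSc3nc4ccccc4s3)cc(=O)c2c1`, is not yet measured; it differs from compound 1 by methyl in place of chloro on an aromatic carbon, the same change as the one that turns compound 3 into compound 2, in the same surroundings. The step from compound 1 to compound 4 is expected to be small, a step that the limit leaves unreadable from compound 1 to compound 4, because the matching step that the two limits leave unreadable from compound 3 to compound 2 and the limit of > 25000 nM in this assay, at which 3 of the 3 values shown sit, give no sign of any gain. Compound 4 is therefore expected to give about 40000 nM, between 15000 nM and 120000 nM, and most likely to be reported only as a limit.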

Compound 4, half-maximal inhibitory concentration: > 25000 nM
Compound 4 gave a limit, no number; the forecaster's own chance of this, stated with the estimate: 85%; the middle value lies beyond the limit too.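

Compound 1 and compound 4 each give only a limit, not a number, so no new step can be read from putting methyl in place of chloro between them: the limit of > 25000 nM in this assay, at which 4 of the 4 values shown sit. Left open is how strongly any of these four compounds acts on these cells, and whether methyl in place of chloro changes that at all.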